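Working notes on cytotoxicity of compounds 1 to 4

This account rests on a few compounds, and the source may have more. Where it says the series, first, only, none or still open, it means among the compounds named here.

Measured so far:
- compound 1 `Cc1nc(-c2cccnc2)sc1-c1nnc(-c2ccncc2)o1`: in an ADME assay on PANC-1 cells (Homo sapiens) for cytotoxicity, read by MTT assay (on this read-out higher numbers stand for lower toxicity in this test and lower numbers for higher toxicity in this test), compound 1 gives > 100 ug/mL, which is a limit of the assay and not a number.
- compound 2 `Cc1ccc(-c2nnc(-c3sc(-c4cccnc4)nc3C)o2)cc1`: in this assay compound 2 gives > 100 ug/mL, again a limit of the assay.
- compound 3 `Cc1nc(-c2cccnc2)sc1-c1nnc(-c2ccccc2)o1`: in this assay compound 3 gives > 100 ug/mL, also a limit of the assay.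

Compound 3 therefore stands where every measured value of the series sits, at the limit of > 100 ug/mL in this assay, at which 3 of the 3 values shown sit. Nothing sets it apart from compound 1 or compound 2 on the numbers shown. The three steps among the measured compounds are all left unreadable by the limits: a step that the two limits leave unreadable from compound 1 to compound 2, a step that the two limits leave unreadable from compound 1 to compound 3 and a step that the two limits leave unreadable from compound 2 to compound 3. None of them gives a size, so none gives a direction.

The next compound is compound 4 `Cc1nc(-c2cccnc2)sc1-c1nnc(-c2ccccc2[N+](=O)[O-])o1`. It differs from compound 3 by nitro in place of hydrogen on an aromatic carbon.

For the measured compounds named here, no measured step bears on a change of this kind, and the three steps that exist could not be read. The only ground for an expectation is that the whole series sits at the limit. On that ground compound 4 is expected to sit at or near the limit in this assay as well, with the estimate 100 ug/mL in a range from 40 ug/mL to 250 ug/mL. The step from compound 3 that this estimate means, a number no higher from compound 3 to compound 4 (the limit leaves the size open), is expected to lie within the scatter.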

Compound 4, half-maximal cytotoxic concentration: > 100 ug/mL
Compound 4: a limit, no number; the forecaster's own chance of this, stated with the estimate: 70%; the middle value lies on the limit itself.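

Compound 3 and compound 4 both give a limit of the assay and not a number in this assay, so no new step can be read between them: the limit of > 100 ug/mL in this assay, at which 4 of the 4 values shown sit.

The compounds shown leave open whether nitro in place of hydrogen, or any other change in the series, alters cytotoxicity at all.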